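Swapping the bromophenyl for a methoxyphenyl on the amine

The source may report more compounds than this note shows. Statements on the series, on what has been measured and on what is new or still open speak of the compounds shown alone.

Compound 1 `C=C1[C@@H](OC(C)=O)C[C@@H]2[C@](C)(CO[Si](C)(C)C(C)(C)C)[C@H](OC(C)=O)CC[C@@]2(C)[C@@H]1C[C@@H](Nc1ccc(Br)cc1)C1=CCOC1=O` was tested in a functional assay on A549 cells (Homo sapiens) for cytotoxicity, read by sulforhodamine B assay (on this read-out lower numbers stand for stronger inhibition and higher numbers for weaker inhibition), and gave 4150 nM. Of the two numbers recorded, compound 1 has the lowest. Its closest neighbour is compound 3 `C=C1[C@@H](OC(C)=O)C[C@@H]2[C@](C)(COC=O)[C@H](OC(C)=O)CC[C@@]2(C)[C@@H]1C[C@@H](Nc1ccc(Br)cc1)C1=CCOC1=O`, which in this assay gives 15900 nM; that pair forms the step of a 3.8-fold higher number from compound 1 to compound 3 (0.58 log units; beyond the scatter). Compound 2 `C=C1[C@@H](OC(C)=O)C[C@@H]2[C@](C)(COC=O)[C@H](OC(C)=O)CC[C@@]2(C)[C@@H]1C[C@@H](Nc1ccc(OC)c(OC)c1)C1=CCOC1=O` reaches only a limit of this assay, > 50000 nM, rather than a number. The comparison of compound 2 with compound 3 gives an at least 3.1-fold lower number from compound 2 to compound 3 (0.49 log units; beyond the scatter), a step that rests on (the limit of > 50000 nM in this assay, at which 1 of the 3 values shown sits).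

Compound 4 `C=C1[C@@H](OC(C)=O)C[C@@H]2[C@](C)(CO[Si](C)(C)C(C)(C)C)[C@H](OC(C)=O)CC[C@@]2(C)[C@@H]1C[C@@H](Nc1cccc(OC)c1)C1=CCOC1=O` differs from compound 1 by 3-methoxyphenyl in place of 4-bromophenyl on an amine nitrogen. Among the measured compounds shown here, the step that bears on this change is the one from compound 2 to compound 3, where the 4-bromophenyl gave the clearly lower number. The change toward compound 4 runs the opposite way, from 4-bromophenyl back to a methoxy-bearing ring, though with a single methoxy group. A modest rise in the number is therefore expected. Compound 4 is expected to give about 12000 nM in this assay, most likely between 4000 nM and 40000 nM, which would be a step of a 2.9-fold higher number from compound 1 to compound 4 (0.46 log units; beyond the scatter).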

Compound 4, half-maximal inhibitory concentration: 17200 nM
Compound 4: middle estimate off by 1.4-fold (0.16 log units), on the low side; the range from low to high includes it.
By their numbers in this assay, from the lowest: compound 1; then compounds 3 and 4 (each within the scatter of the next). At a limit, above all of these: compound 2.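

The step of a 4.1-fold higher number from compound 1 to compound 4 (0.62 log units; beyond the scatter) in this assay puts a measured size on moving away from the 4-bromophenyl group on the amine nitrogen, with a real number at both ends. The earlier comparison of aryl groups on this nitrogen could not do that, because one end of it was only a limit: the limit of > 50000 nM in this assay, at which 1 of the 4 values shown sits. The lower number with 4-bromophenyl now also appears in a second pair, since compound 1 and compound 4 carry the silicon-containing group where compound 2 and compound 3 carry a smaller one, and neither pair goes against this.

On these data alone, whether the rise follows from losing the bromine or from where the ring substituent sits stays open, and 3-bromophenyl, 4-methoxyphenyl or plain phenyl would separate the two. The compounds shown give no measured reason for the rise.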